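A few compounds are considered here, and "the series" means these few. Any claim that something is new, unique, unknown or untested is made for them only; others in the source may bear on it.

Measured so far in a functional assay on THP-1 cells (Homo sapiens) for cytotoxicity, read by MTT assay, with a stated time of 72 h; a higher number here means a weaker inhibitor, a lower number a stronger inhibitor: compound 1 `COc1ccc(/C=C2\CC[C@H]3C(C)(C)CCC[C@]3(C)[C@H]2CCC(C)CC(=O)O)cc1`, compound 2 `Cc1ccc(/C=C2\CC[C@H]3C(C)(C)CCC[C@]3(C)[C@H]2CCC(C)CC(=O)O)cc1`, compound 3 `CC(CC[C@H]1/C(=C/c2ccc([N+](=O)[O-])cc2)CC[C@H]2C(C)(C)CCC[C@]12C)CC(=O)O`.

Compound 1 gives only a limit of this assay, > 200000 nM. Compound 2 gives 91000 nM. Compound 3 gives 68000 nM, and against compound 2 the gap is a 1.3-fold lower number from compound 2 to compound 3 (0.13 log units; within the scatter), so the two numbers cannot be ranked.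

Compound 4 `COc1ccc(/C=C2\CC[C@H]3C(C)(C)CCC[C@]3(C)[C@H]2CCC(C)CC(=O)O)cc1OC` is not yet measured. The change is 3,4-dimethoxyphenyl in place of 4-nitrophenyl on a double-bonded chain carbon bound to a double-bonded ring carbon. The step that bears on it runs the other way: an at least 2.9-fold lower number from compound 1 to compound 3 (0.46 log units; beyond the scatter), with the limit of > 200000 nM in this assay, at which 1 of the 3 values shown sits, meaning only a bound is known. Reversing it, methoxy back in place of nitro, points to a higher number in this assay; the second methoxy is covered by no measured step. The step expected is a 2.2-fold higher number from compound 3 to compound 4 (0.34 log units; beyond the scatter), with a real chance of a limit. Compound 4 is estimated at 150000 nM, range 60000 nM to 400000 nM.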

Compound 4, half-maximal inhibitory concentration: 106000 nM
Compound 4: middle estimate off by 1.4-fold (0.15 log units), on the high side; the measured number falls inside the stated range.
By their numbers in this assay, from the lowest: compounds 3, 2 and 4 (each within the scatter of the next). At a limit, above all of these: compound 1.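

In this assay, 3,4-dimethoxyphenyl on a double-bonded chain carbon bound to a double-bonded ring carbon gives a 1.6-fold higher number from compound 3 to compound 4 (0.19 log units; within the scatter) and a 1.2-fold higher number from compound 2 to compound 4 (0.07 log units; within the scatter), so the three aryl groups cannot be separated at this position. Compound 4 carries two methoxy groups and still returns a number. The methoxy-for-hydrogen step gives an at least 1.8-fold lower number from compound 1 to compound 4 (0.27 log units; that floor lies within the scatter), so it cannot be read. Compound 1 gives > 200000 nM, which is a limit: the limit of > 200000 nM in this assay, at which 1 of the 4 values shown sits.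

Open, on these data alone, is whether an amine or chlorine on the aromatic ring would separate from these three groups. Also open is what replacing the carboxylic acid, common to all the compounds shown, would do.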